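The compounds below may be only part of what the source reports. "The series", "measured", "known", "first", "only" and "open" are said of these compounds alone.

Working notes on the dichlorinated benzimidazole series, cytotoxicity arm. Two compounds of the shared core carry a number in an ADME assay on MT4 cells (Homo sapiens) for cytotoxicity, read by MTT assay, with a stated time of 96 h; on this read-out higher numbers stand for lower toxicity in this test and lower numbers for higher toxicity in this test. Compound 1 `COc1ccc(-c2nc3cc(Cl)c(Cl)cc3[nH]2)cc1` in this assay gives 1000 nM. For the measured compounds named here, compound 2 `O=C(CN1CCCC1)Nc1ccc(-c2nc3cc(Cl)c(Cl)cc3[nH]2)cc1` in this assay gives 8000 nM, the higher of the two numbers so far, and the gap to compound 1 lies beyond the scatter of the method; no single-point step connects these two compounds, so the two values stand side by side without a computed step.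

Compound 3 `CC(=O)Nc1ccc(-c2nc3cc(Cl)c(Cl)cc3[nH]2)cc1` has not been measured in this assay. Against compound 2 the difference is hydrogen in place of pyrrolidin-1-yl on a saturated chain carbon bound to a carbonyl carbon. No measured pair in the set differs at this place, so nothing shown fixes the size of the step. The expectation is a step downward in this assay from compound 2 to compound 3 of a 2.3-fold lower number from compound 2 to compound 3 (0.36 log units; beyond the scatter), of a size that may sit at the edge of the scatter, since compound 2 gives 8000 nM and compound 1, lacking the acetyl group entirely, gives 1000 nM. For compound 3 the estimated value in this assay is 3500 nM, with a range from 1000 nM to 15000 nM.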

Compound 3, half-maximal cytotoxic concentration: > 100000 nM
Compound 3 ended at the assay's limit (the forecaster's own chance of this, stated with the estimate: 10%); middle value at least 28-fold (1.45 log units) away from the limit.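

For the compounds shown here, on a saturated chain carbon bound to a carbonyl carbon, the change from pyrrolidin-1-yl to hydrogen in this assay brings an at least 12-fold higher number from compound 2 to compound 3 (1.09 log units; beyond the scatter), so this one place moves the read-out strongly towards lower toxicity in this test, which compounds 1 and 2, joined by no step, could not show. On an aromatic carbon, acetamido in place of methoxy brings an at least 100-fold higher number from compound 1 to compound 3 (2.00 log units; beyond the scatter), which places compound 3 highest of the three on this read-out, with the acetyl chain free of pyrrolidin-1-yl. Both steps are minimum sizes, as the value of compound 3 is a limit of the assay and not a number: the limit of > 100000 nM in this assay, at which 1 of the 3 values shown sits.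

Going by these compounds, how far compound 3 lies past that limit stays open, and with it the true size of both steps. Also open, on these data alone, is whether the lower number of compound 2 follows from the pyrrolidin-1-yl ring itself or from any amine on that carbon; a dimethylamino group, a piperidine ring or a longer chain at the same place would separate these readings.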